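The source may hold more compounds than are shown below. What is called first, only, known or untested is meant among the compounds shown, and "the series" means these compounds.

Compound 1 `CC[C@H](C)[C@H](N)CN(C(=O)[C@@H]1C[C@H]1c1ccccc1F)c1ccc(-c2ccccc2)cc1`: 650 nM
Compound 2 `CC[C@H](C)[C@H](N)CN(C(=O)[C@@H]1C[C@H]1c1cncnc1)c1ccc(-c2ccccc2)cc1`: 19000 nM
Compound 3 `CC(C)C[C@H](N)CN(C(=O)[C@@H]1C[C@H]1c1ccccc1)c1ccc(-c2cccnc2)cc1`: 10000 nM

All three were tested in a functional assay for agonist activity at G protein-coupled receptor 88 (Homo sapiens), read by HTRF and cAMP accumulation; on this read-out higher numbers stand for an effect only at larger amounts of compound and lower numbers for an effect already at smaller amounts. Compound 3 has the second highest number of the three; its value and that of compound 2 lie within the scatter of each other, while compound 1 gives a much lower number. Compound 4 `CC(C)C[C@H](N)CN(C(=O)[C@@H]1C[C@H]1c1ccccc1)c1ccc(-c2ccc(F)cc2)cc1` differs from compound 3 in one place: 4-fluorophenyl in place of pyridin-3-yl on an aromatic carbon. Among the measured compounds shown here, no measured step touches this position. For the measured compounds named here, the one step that was measured, a 29-fold higher number from compound 1 to compound 2 (1.47 log units; beyond the scatter), exchanged a carbon-only ring for a ring with nitrogen at another place and raised the number strongly. Compound 4 makes the opposite kind of exchange, so a lower number is expected, a step of roughly a 10-fold lower number from compound 3 to compound 4 (1.00 log units; beyond the scatter). For compound 4 the estimate in this assay is 1000 nM, between 250 nM and 4000 nM.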

Compound 4, half-maximal effective concentration: 900 nM
Compound 4: middle estimate off by 1.1-fold (0.05 log units), on the high side; the measured number falls inside the stated range.
By their numbers in this assay, from the lowest: compounds 1 and 4 (each within the scatter of the next); then compounds 3 and 2 (each within the scatter of the next).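

In this assay, among the compounds shown here, the only earlier step changed a group on a saturated ring carbon, whereas an 11-fold lower number from compound 3 to compound 4 (1.05 log units; beyond the scatter) shows that the group on this aromatic carbon can also move the number strongly. Here too the ring with nitrogen goes with the higher number, though at a different place in the molecule. Nothing available explains the size of this step.

Going by these compounds, the step removes the ring nitrogen and adds fluorine at once, so their separate shares stay open. So does the outcome with 4-chlorophenyl or 4-methoxyphenyl here.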